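The source may report more compounds than this note shows. Statements on the series, on what has been measured and on what is new or still open speak of the compounds shown alone.

Of the compounds shown here, three built on one shared core have been tested in an assay on CHO cells for displacement of a labelled ligand from adenosine receptor A3 (Homo sapiens), read by scintillation counting, with a stated time of 120 min, tested at 1 uM; a higher number here means more inhibition at the concentration tested (going by the name of the read-out), a lower number less inhibition. Compound 1 `CCn1nc(-c2ccccn2)c2sccc2c1=O` gives 1% in this assay. Compound 2 `CCn1nc(-c2cccs2)c2sccc2c1=O` gives 1%, so the step of no change at the digits printed from compound 1 to compound 2 (within the scatter), in which thiophen-2-yl replaces pyridin-2-yl on an aromatic carbon, left the read-out flat. Compound 3 `Nn1nc(-c2cccs2)c2sccc2c1=O` gives 1%, and the step of no change at the digits printed from compound 2 to compound 3 (within the scatter), amino in place of ethyl on an aromatic nitrogen, again changed nothing. Compound 3 therefore stands level with compound 1 and compound 2: all three show essentially no displacement of the labelled ligand at the tested concentration.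

Compound 4 `Nn1nc(-c2nccs2)c2sccc2c1=O` differs from compound 3 in a single place: 1,3-thiazol-2-yl in place of thiophen-2-yl on an aromatic carbon. Among the measured compounds shown here, the step that bears most on this is the one from compound 1 to compound 2, where one five-membered or six-membered aromatic ring was swapped for another on the same aromatic carbon, and it produced no movement. For the measured compounds named here, nothing measured so far suggests that a ring swap at this position moves the read-out beyond the scatter. Compound 4 is therefore expected to give 3% in this assay, within the range -8% to 15%. The estimated step of a number 2 percentage points higher from compound 3 to compound 4 (within the scatter) is expected to stay within the scatter.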

Compound 4, a percentage reported as inhibition, at one concentration (the size of the read-out at that concentration, not a potency): 5%
For compound 4 the middle estimate is 2 percentage points below the measured one; the range from low to high includes it.
By their numbers in this assay, from the lowest: compounds 1, 2, 3 and 4 (each within the scatter of the next).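

In this assay, 1,3-thiazol-2-yl in place of thiophen-2-yl on this aromatic carbon gives a number 4 percentage points higher from compound 3 to compound 4 (within the scatter). The earlier ring swap at this carbon was read with ethyl on the ring nitrogen, whereas this one is read with amino there and brings in a five-membered ring with a second hetero atom, so the flat result now extends to a third aromatic ring and to a second group on that nitrogen. Nothing available explains why the read-out stays flat with this change.

From the compounds shown here alone, all four compounds show very little inhibition, so it remains open whether these rings would differ on a compound that displaces the labelled ligand strongly. Also open, going by these compounds, is whether a phenyl ring at this carbon, or a benzyl group or longer chain on the ring nitrogen, would raise the read-out.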